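A Sulfonyl Substituent Exchanged in a Growth Inhibition Series

The source may hold more compounds than are shown below. What is called first, only, known or untested is meant among the compounds shown, and "the series" means these compounds.

In a functional assay on DU-145 cells (Homo sapiens) for inhibition, read by trypan blue exclusion, with a stated time of 96 h (a higher number here means a weaker inhibitor of growth, a lower number a stronger inhibitor of growth), compound 1 `O=C(/C(=C\c1ccccc1OCc1ccccc1)S(=O)(=O)Cc1ccc(F)cc1)c1ccc(Cl)cc1` gives 10000 nM, the lowest of the two numbers available. The nearest number comes from compound 2 `CN(C)c1ccc(/C=C(/SCc2ccc(F)cc2)C(=O)c2ccc(Br)cc2)cc1`, at 50000 nM, and that gap lies beyond the scatter. Compound 3 `CN(C)c1ccc(/C=C(/SCc2ccc(Cl)cc2)C(=O)c2ccc([N+](=O)[O-])cc2)cc1` is reported only as a limit, > 100000 nM.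

Compound 4 `COc1ccc(S(=O)(=O)/C(=C/c2ccccc2OCc2ccccc2)C(=O)c2ccc(Cl)cc2)cc1` keeps the core of compound 1 and alters a single place: 4-methoxyphenyl in place of 4-fluorobenzyl on a sulfonyl sulfur. The change puts 4-methoxyphenyl in place of 4-fluorobenzyl on a sulfonyl sulfur. Going by the values given here, no measured pair in this assay isolates a change of this kind, so the expectation rests on compound 1 alone, with its 10000 nM as the anchor. A step within the scatter is expected, leaning slightly towards a higher number, although a larger loss cannot be ruled out. The estimated step runs a 1.5-fold higher number from compound 1 to compound 4 (0.18 log units; within the scatter). For compound 4 the expected value is 15000 nM, with an estimated range from 3000 nM to 70000 nM.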

Compound 4, concentration for 50% growth inhibition: 1000 nM
The estimate for compound 4 lay 15-fold (1.18 log units) above the measured number; measured number outside the range, below it.
By their numbers in this assay, from the lowest: compound 4; then compound 1; then compound 2. At a limit, above all of these: compound 3.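

The exchange of 4-fluorobenzyl for 4-methoxyphenyl on a sulfonyl sulfur gives a 10-fold lower number from compound 1 to compound 4 (1.00 log units; beyond the scatter) in this assay. Going by these compounds alone, this is the first pair to differ in one place, and it shows that the group on this sulfonyl sulfur can shift the number well beyond the scatter, though only a single pair supports this. Nothing measured here bears on why the exchange has this effect.

The exchange replaces 4-fluorobenzyl with 4-methoxyphenyl as a whole, so the pair cannot separate the part played by the methoxy group and the fluorine from that of the benzyl and phenyl frames. Still open, from the compounds shown here alone, is how 4-fluorophenyl, 4-methoxybenzyl or an amine such as 4-aminophenyl would read on the same sulfonyl sulfur.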